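Working notes: compound 3 to compound 4

The compounds below may be only part of what the source reports. "The series", "measured", "known", "first", "only" and "open" are said of these compounds alone.

In an ADME assay on HEK293 cells (Homo sapiens) for cytotoxicity, read by reporter gene assay and resazurin assay, with a stated time of 48 h (a lower number here means that less compound is tolerated, a higher number that more compound is tolerated), compound 1 `O=C(Nc1ccc(Sc2nc3ccccc3s2)cc1)c1ccccc1` reads > 100000 nM, a limit of the assay. Compound 3 `O=C(Nc1ccc(Sc2nc3ccccc3s2)cc1)c1cccc(Br)c1O` gives 71000 nM and compound 2 `O=C(Nc1ccc(Sc2nc3ccccc3s2)c(Cl)c1)c1cc(Br)cc(Br)c1O` gives 76000 nM, two values within the scatter of each other. Compound 4 `O=C(Nc1ccc(Sc2nc3ccccc3s2)cc1)c1cc(Br)cc(Br)c1O` differs from compound 3 by one change: bromo in place of hydrogen on an aromatic carbon, with 3-bromo-2-hydroxyphenyl becoming 3,5-dibromo-2-hydroxyphenyl. Within the data shown here, the only measured step is an at least 1.4-fold lower number from compound 1 to compound 3 (0.14 log units; that floor lies within the scatter), and it gives no firm size. Compound 2 already carries 3,5-dibromo-2-hydroxyphenyl and gives 76000 nM, so a large drop seems unlikely. The expected 1.2-fold lower number from compound 3 to compound 4 (0.09 log units; within the scatter) in this assay stays within the scatter. Compound 4 is estimated at 58000 nM, with an expected range of 27000 nM to 100000 nM.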

Compound 4, half-maximal cytotoxic concentration: 66000 nM
Compound 4: middle estimate off by 1.1-fold (0.06 log units), on the low side, and the stated range covers the measured number.
By their numbers in this assay, from the lowest: compounds 4, 3 and 2 (each within the scatter of the next). At a limit, above all of these: compound 1.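

In this assay, a second bromo on this ring, para to the hydroxy group, leaves the number essentially unmoved: a 1.1-fold lower number from compound 3 to compound 4 (0.03 log units; within the scatter). Removing the chloro group of compound 2 likewise stays within the scatter: a 1.2-fold lower number from compound 2 to compound 4 (0.06 log units; within the scatter). The step from phenyl, an at least 1.5-fold lower number from compound 1 to compound 4 (0.18 log units; that floor lies within the scatter), rests on a limit for compound 1 and gives no firm size: the limit of > 100000 nM in this assay, at which 1 of the 4 values shown sits.

Open, going by these compounds, is whether an amine or a carboxylic acid at this place would move the number beyond the scatter. The compounds shown also do not separate the hydroxy group's contribution from that of the bromo groups.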